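Phenoxy in place of chloro: from compound 1 toward compound 4

A few compounds are considered here, and "the series" means these few. Any claim that something is new, unique, unknown or untested is made for them only; others in the source may bear on it.

Measured so far in an assay on isolated protein for inhibition of Indoleamine 2,3-dioxygenase 1 (Homo sapiens), read by spectrophotometry; a lower number here means a stronger inhibitor, a higher number a weaker inhibitor:
compound 1 `O/N=C(/Nc1cccc(Cl)c1)c1ccc2occc2c1` — 690 nM
compound 2 `O/N=C(/Nc1ccc(F)c(F)c1)c1ccc2occc2c1` — 22700 nM
compound 3 `O=C(NCc1ccccc1)c1cccc(N/C(=N/O)c2ccc3occc3c2)c1` — > 30000 nM, a limit of the assay, not a number

Of the two numbers in hand, compound 1 holds the lower one; compound 2 stands well above it, by a margin beyond the usual scatter of this assay. Compound 3 sits at the limit of > 30000 nM in this assay, at which 1 of the 3 values shown sits. No pair among these three differs in a single place, so no measured step is available to calibrate the next change.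

The untested member is compound 4 `O/N=C(/Nc1cccc(Oc2ccccc2)c1)c1ccc2occc2c1`. It differs from compound 1 by phenoxy in place of chloro on an aromatic carbon. The entering group is far larger than the one it replaces. Compound 3, whose structure also departs most from compound 1 on that same ring, sits at the limit of > 30000 nM in this assay, at which 1 of the 3 values shown sits, and on that showing a larger substituent is expected to weaken inhibition in this assay rather than strengthen it.

Compound 4 is therefore estimated at 5000 nM, with a likely range from 1000 nM to 30000 nM. The expected step of a 7.2-fold higher number from compound 1 to compound 4 (0.86 log units; beyond the scatter) is toward a higher number, beyond the scatter, with a real chance that only a limit is returned.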

Compound 4, half-maximal inhibitory concentration: > 30000 nM
Compound 4 ended at the assay's limit; the forecaster's own chance of this, stated with the estimate: 20%; middle value at least 6.0-fold (0.77 log units) away from the limit.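

Among the compounds shown here, this is the first single-place step: at the aromatic carbon meta to a large group, phenoxy in place of chloro gives an at least 43-fold higher number from compound 1 to compound 4 (1.63 log units; beyond the scatter), so what stands at this position decides whether the core of compound 1 retains measurable inhibition. In this assay compound 4 gives > 30000 nM, a limit of the assay and not a number, and it is now one of two compounds there: the limit of > 30000 nM in this assay, at which 2 of the 4 values shown sit. The step therefore fixes its direction and a minimum size only, and the true size of the loss cannot be read from it.

The compounds shown leave open where between chloro and phenoxy the loss sets in, which a methyl, methoxy or bromo group at the same carbon would begin to settle. They also leave open whether the loss follows the added phenyl ring or the ether oxygen, a question that a benzyl or a cyclohexyloxy group in place of phenoxy would address, and whether the unsubstituted phenyl ring already inhibits less well than compound 1, which gives 690 nM.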